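The compounds below may be only part of what the source reports. "The series", "measured", "known", "first", "only" and "open" are said of these compounds alone.

Measured to date in an ADME assay on microsomes from liver (Homo sapiens) for metabolic stability, tested at 2.5 uM; a higher number here means faster removal of the compound, a lower number slower removal:
Compound 1, `COc1cccc(-c2c(S(=O)(=O)c3cc(F)cc(F)c3)cnc3cc(F)ccc23)c1`: 1.81 mL/min
Compound 2, `COc1cccc(-c2c(S(=O)(=O)c3ccc(C)c(C)c3)cnc3cc(F)ccc23)c1`: 8.78 mL/min
Compound 3, `COc1cccc(-c2c(S(=O)(=O)c3cccc(C#N)c3)cnc3cc(F)ccc23)c1`: 1.83 mL/min

Compound 2 gives the highest of the three numbers in this assay; the steps of a 4.9-fold higher number from compound 1 to compound 2 (0.69 log units; beyond the scatter) and a 4.8-fold lower number from compound 2 to compound 3 (0.68 log units; beyond the scatter) are both beyond the scatter, while a 1.0-fold higher number from compound 1 to compound 3 (0.00 log units; within the scatter) lies within it. Compound 4, `Cc1ccc(S(=O)(=O)c2cnc3cc(F)ccc3c2-c2cccc(F)c2)cc1C`, differs from compound 2 by fluoro in place of methoxy on an aromatic carbon. Going by the values given here, every measured step changes the group on the sulfonyl sulfur; none alters the methoxy, so no measured step bears on this change, and the series gives no indication of direction for this assay. A step of no more than the scatter is therefore the working expectation, a 1.3-fold lower number from compound 2 to compound 4 (0.10 log units; within the scatter). The expected value for compound 4 in this assay is 7 mL/min, with a range of 3 mL/min to 15 mL/min.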

Compound 4, intrinsic clearance in a liver preparation (reported as CLH), per the amount of preparation that the assay uses: 3.71 mL/min
Beside the measured number, compound 4's estimate is 1.9-fold (0.28 log units) above it; measured number inside the range.
By their numbers in this assay, from the lowest: compounds 1 and 3 (each within the scatter of the next); then compound 4; then compound 2.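

In this assay the group on the sulfonyl sulfur is not the only site that moves the number: with 3,4-dimethylphenyl held fixed, 3-fluorophenyl in place of 3-methoxyphenyl gives a 2.4-fold lower number from compound 2 to compound 4 (0.37 log units; beyond the scatter) and a step beyond the scatter. Going by these compounds alone, this is the first reading of a change on this ring, so the place meta to a large group counts as responsive in this one pair. Nothing at hand gives a reason for the step.

Still open, going by these compounds, is whether the step carries over with 3,5-difluorophenyl or 3-cyanophenyl on the sulfonyl sulfur. Also open, on these data alone, is how chloro, hydroxyl or an amine would read at this place.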